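This account rests on a few compounds, and the source may have more. Where it says the series, first, only, none or still open, it means among the compounds named here.

In a functional assay on DU-145 cells (Homo sapiens) for inhibition, read by MTT assay, with a stated time of 72 h (on this read-out higher numbers stand for weaker inhibition of growth and lower numbers for stronger inhibition of growth), the three measured compounds give only modest numbers. Compound 1 `N#C/C(=C\c1c[nH]c2ccccc12)C(=O)c1c[nH]c2ccccc12` gives 17000 nM, and compound 3 `COc1ccc(CNC(=O)/C(C#N)=C/c2ccco2)cc1` gives 29000 nM. For compound 2 `N#C/C(=C\c1ccc[nH]1)C(=O)NCc1ccc(Cl)c(Cl)c1` this assay reports no number but only a limit, > 50000 nM, so compound 2 sits at the limit of > 50000 nM in this assay, at which 1 of the 3 values shown sits, and stands, as far as the numbers show, no stronger than the other two and possibly weaker. Compound 4 `N#C/C(=C\c1ccccc1)C(=O)NCc1ccc(Cl)c(Cl)c1` has not yet been measured in this assay; it differs from compound 2 in one place, (phenyl in place of 1H-pyrrol-2-yl on a double-bonded chain carbon bound to a double-bonded chain carbon). Going by the values given here, no measured pair shows this same exchange, so the size of the step can only be guessed. The two measured compounds that do give numbers, compound 1 and compound 3, both lie within a narrow band, and compound 2 is left open beyond the limit; the step from compound 2 to compound 4 is therefore expected to be small or at most a modest gain, an at least 1.2-fold lower number from compound 2 to compound 4 (0.09 log units; that floor lies within the scatter). Compound 4 is estimated at 40000 nM, within a range from 15000 nM to 100000 nM, with a fair chance that this assay again reports only a limit.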

Compound 4, concentration for 50% growth inhibition: 71000 nM
Compound 4: middle estimate off by 1.8-fold (0.25 log units), on the low side, within the range that was stated.
By their numbers in this assay, from the lowest: compounds 1 and 3 (each within the scatter of the next); then compound 4.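

No step can be read from compound 2 to compound 4 in this assay, because compound 2 carries only a limit: the limit of > 50000 nM in this assay, at which 1 of the 4 values shown sits.

The compounds shown leave open whether phenyl in place of 1H-pyrrol-2-yl changes the number in this assay at all, and in which direction.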